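Swapping Methoxy for Methyl on the Sulfonamide Aryl Ring

This account rests on a few compounds, and the source may have more. Where it says the series, first, only, none or still open, it means among the compounds named here.

Compound 1, `O=C1NCCN1c1ccc(S(=O)(=O)Nc2ccc(Br)cc2)cc1`: 240 nM in a functional assay on MCF7 cells (Homo sapiens) for antiproliferative activity, read by sulforhodamine B assay, with a stated time of 48 h; on this read-out lower numbers stand for stronger inhibition and higher numbers for weaker inhibition
Compound 2, `COc1cccc(NS(=O)(=O)c2ccc(N3CCNC3=O)cc2)c1`: 120 nM

Within the data shown here, compound 2 has the lowest of the two numbers, but its only neighbour, compound 1, lies within the scatter of it: a 2.0-fold lower number from compound 1 to compound 2 (0.30 log units; within the scatter). Compound 3, `Cc1cccc(NS(=O)(=O)c2ccc(N3CCNC3=O)cc2)c1`, differs from compound 2 by methyl in place of methoxy on an aromatic carbon. Among the measured compounds shown here, no measured step makes this exact exchange; the one step known, from compound 1 to compound 2, altered the group on the same ring and stayed within the scatter. So for compound 3 a step within the scatter is expected in this assay: a 1.3-fold higher number from compound 2 to compound 3 (0.10 log units; within the scatter). Compound 3 is therefore estimated at 150 nM, between 60 nM and 400 nM.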

Compound 3, half-maximal inhibitory concentration: 190 nM
For compound 3 the middle estimate is 1.3-fold (0.10 log units) below the measured one, within the range that was stated.
By their numbers in this assay, from the lowest: compounds 2, 3 and 1 (each within the scatter of the next).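

Replacing methoxy with methyl removes one hydrogen-bond acceptor at this position, yet the exchange gives a 1.6-fold higher number from compound 2 to compound 3 (0.20 log units; within the scatter) in this assay, so these two groups cannot be told apart here. Changing 4-bromophenyl to 3-methylphenyl gives a 1.3-fold lower number from compound 1 to compound 3 (0.10 log units; within the scatter), which means that all three aryl groups shown read alike. Nothing available explains this sameness.

Still open, on these data alone, is whether an amine, a carboxylic acid or a longer chain on this ring would shift the number beyond the scatter.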